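Solubility notes: from compound 3 to compound 4

A few compounds are considered here, and "the series" means these few. Any claim that something is new, unique, unknown or untested is made for them only; others in the source may bear on it.

Compound 3 `COc1cccc(CN2C(=O)CN(C(=O)c3cc4cc(OC)ccc4[nH]3)C[C@@H]2CCc2ccccc2)c1` holds the highest of the three numbers in a physicochemical assay for solubility, read by spectrophotometry, in phosphate buffer, with a stated time of 2 h, at pH 7.4 (on this read-out higher numbers stand for higher solubility and lower numbers for lower solubility), giving 5100 nM. Compound 1 `COc1cccc(CN2C(=O)CN(C(=O)c3cc4cc(OC)ccc4o3)C[C@@H]2CCc2ccccc2)c1` gives 4900 nM and compound 2 `COc1ccc2[nH]c(C(=O)N3CC(=O)N(Cc4ccccc4)[C@@H](CCc4ccccc4)C3)cc2c1` gives 4400 nM. Both measured steps toward compound 3 sit within the scatter: a 1.0-fold higher number from compound 1 to compound 3 (0.02 log units; within the scatter) and a 1.2-fold higher number from compound 2 to compound 3 (0.06 log units; within the scatter), so no ordering among the three is claimed.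

Compound 4 `COc1cccc(CN2C(=O)CN(C(=O)c3cc4cc(OC)ccc4[nH]3)C[C@@H]2Cc2ccccn2)c1` differs from compound 3 in one place: pyridin-2-yl in place of benzyl on a saturated chain carbon bound to a saturated ring carbon. Among the measured compounds shown here, neither measured step touches this place, so no step bears directly on it; both were within the scatter. Given the hydrogen-bond acceptor counted as entering, a small upward step is expected, a 1.5-fold higher number from compound 3 to compound 4 (0.17 log units; within the scatter), near the edge of the scatter. Compound 4 is estimated at 7500 nM, with a range from 3000 nM to 18000 nM.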

Compound 4, solubility: 57900 nM
The estimate for compound 4 lay 7.7-fold (0.89 log units) below the measured number, and the stated range ends below it.
By their numbers in this assay, from the lowest: compounds 2, 1 and 3 (each within the scatter of the next); then compound 4.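

In this assay this place, on a saturated chain carbon bound to a saturated ring carbon, gives an 11-fold higher number from compound 3 to compound 4 (1.06 log units; beyond the scatter) and is the only place shown where a step lies beyond the scatter. Both earlier steps, at other places, stayed within it. Cut one bond further out, the change reads phenethyl to (pyridin-2-yl)methyl, so chain length and ring change together in this one step.

Open, as far as these compounds go, is which of the two carries the step, something a 2-(pyridin-2-yl)ethyl group at this place would separate. No measurement shown gives a cause for the step.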